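The compounds below may be only part of what the source reports. "The series", "measured", "known", "first", "only" and "open" are said of these compounds alone.

Compound 2 `CNC(=O)c1cc(C(=O)NCCC2CCOCC2)cn(Cc2ccccc2)c1=O` gives 3.6 in a physicochemical assay for lipophilicity, at pH 7.4 (on this read-out lower numbers stand for lower lipophilicity and higher numbers for higher lipophilicity), the highest of the three numbers here. Its nearest neighbour, compound 1 `CNC(=O)c1cc(C(=O)NC2CC2)cn(Cc2cccc(OC)c2)c1=O`, gives 3 in this assay, and compound 3 `CNC(=O)c1cc(C(=O)NC2CC2)cn(CC2CCCOC2)c1=O` gives 2. Among the measured compounds shown here, the one step among the measured compounds that differ in a single place is a number 1.00 log units lower from compound 1 to compound 3 (beyond the scatter). Compound 4 `CNC(=O)c1cc(C(=O)NC)c(=O)n(Cc2ccccc2)c1` has not yet been measured. It differs from compound 2 in that (hydrogen in place of (oxan-4-yl)methyl on a saturated chain carbon bound to an amide-type nitrogen); cut one bond further out, the same change reads 2-(oxan-4-yl)ethyl to methyl on the amide nitrogen. For the measured compounds named here, no measured pair shows exactly this change, but the step from compound 1 to compound 3 shows how a switch between a 3-methoxyphenyl and an oxan-3-yl group registers in this assay. Since compound 4 loses the whole (oxan-4-yl)methyl piece of compound 2 rather than exchanging it, a drop beyond the scatter is expected, estimated as a number 0.80 log units lower from compound 2 to compound 4 (beyond the scatter). Compound 4 is therefore expected to give about 2.8 in this assay, within a range from 2.2 to 3.4.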

Compound 4, distribution coefficient: 2.4
Compound 4: middle estimate off by 0.40 log units, on the high side; the measured number falls inside the stated range.
By their numbers in this assay, from the lowest: compound 3; then compound 4; then compound 1; then compound 2.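

The earlier compounds shown here held no step at this place; hydrogen in place of (oxan-4-yl)methyl on a saturated chain carbon bound to an amide-type nitrogen gives a number 1.20 log units lower from compound 2 to compound 4 (beyond the scatter) in this assay. Set beside a number 1.00 log units lower from compound 1 to compound 3 (beyond the scatter), an exchange on a saturated chain carbon bound to an aromatic nitrogen, the two steps are close in size, so the read-out moves about as far at this place as it did at that one. Nothing available bears on the cause of this step.

The compounds shown leave open whether the step follows from the length of the chain or from the ring, that is, whether a plain propyl chain or a cyclohexyl ring in place of the oxan-4-yl ring would read like compound 2 or like compound 4. Also open, going by these compounds, is how an amine or a carboxylic acid at the end of this chain would read in this assay.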